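The compounds below may be only part of what the source reports. "The series", "measured", "known", "first", "only" and "open" are said of these compounds alone.

Of the compounds shown here, two have been measured. Compound 1 `Cc1c(C#N)c(NCCO)nc2nc(NCCO)nc(N)c12` and compound 2 `N#Cc1cc2c(N)ncnc2nc1Nc1ccc(S(N)(=O)=O)cc1` share the same core but differ at several places at once, so no single change can yet be read from them. In a functional assay on SNU-638 cells (Homo sapiens) for inhibition, read by sulforhodamine B assay, with a stated time of 2 days (on this read-out lower numbers stand for stronger inhibition of growth and higher numbers for weaker inhibition of growth), compound 1 gives 18200 nM, the highest of the two numbers in hand. In this assay compound 2 gives 7570 nM, a step from compound 1 that lies beyond the usual scatter. Going by the values given here, no pair of measured compounds that differ in only one place exists, so the weight of any single change is unknown from these data.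

Compound 3 `N#Cc1cc2c(N)nc(NCCO)nc2nc1NCCO` is the next to be measured. It differs from compound 1 in one place: hydrogen in place of methyl on an aromatic carbon. The group that leaves is a single carbon with no ring, no donors and no acceptors.

Given that compound 1 gives 18200 nM in this assay and that only one heavy atom is removed, compound 3 is expected to stay near it, with the step of a 1.2-fold lower number from compound 1 to compound 3 (0.08 log units; within the scatter) expected to be small and within the scatter, in no firm direction. Compound 3 is therefore estimated at 15000 nM, with a range from 5000 nM to 45000 nM.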

Compound 3, concentration for 50% growth inhibition: 7950 nM
Compound 3: middle estimate off by 1.9-fold (0.28 log units), on the high side; measured number inside the range.
By their numbers in this assay, from the lowest: compounds 2 and 3 (each within the scatter of the next); then compound 1.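

In this assay, going by these compounds alone, the methyl on the aromatic carbon, ortho to a cyano group and opposite the ring nitrogen, proves not to be a neutral feature: exchanging it for hydrogen gives a 2.3-fold lower number from compound 1 to compound 3 (0.36 log units; beyond the scatter), the first single change that can be read. The step is modest, but it shows that this one carbon can be removed with no loss of growth inhibition on these cells, and that the methyl is not required for the activity of compound 1 in this assay. The data at hand offer no measurement that accounts for this step.

The finding rests on a single pair that carries two (2-hydroxyethyl)amino groups, and compound 2 differs from both of its partners in more than one place, so steps to compound 2 cannot be read and the change cannot be extended to other substituents on the shared core. Going by these compounds, what an ethyl group, a chlorine atom or an amine on this same aromatic carbon would give remains open, as does whether hydrogen is the best group at this position.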